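The source may hold more compounds than are shown below. What is called first, only, known or untested is meant among the compounds shown, and "the series" means these compounds.

Within the data shown here, compound 2 `CN(C)CCn1cnnc1-c1cc(Oc2ccc(NC(=O)N/N=C/c3ccccc3)cc2F)ccn1` gives 2730 nM in a functional assay on MKN-45 cells (Homo sapiens) for cytotoxicity, read by MTT assay, with a stated time of 72 h (on this read-out lower numbers stand for stronger inhibition and higher numbers for weaker inhibition), one of only two numbers in this set; compound 1 `COc1ccc(OC)c(/C=N/NC(=O)Nc2ccc(Oc3ccnc(-c4nncn4CCN(C)C)c3)c(F)c2)c1` gives 1510 nM, and the step of a 1.8-fold higher number from compound 1 to compound 2 (0.26 log units; within the scatter) stays within the scatter. Compound 3 `CN(C)CCn1cnnc1-c1cc(Oc2ccc(NC(=O)N/N=C/c3ccc(F)cc3F)cc2F)ccn1` differs from compound 2 by 2,4-difluorophenyl in place of phenyl on a carbon with a double bond to nitrogen. Among the measured compounds shown here, the single measured step that touches this ring, a 1.8-fold higher number from compound 1 to compound 2 (0.26 log units; within the scatter), was within the scatter, so no step beyond the scatter is expected in this assay from the same kind of change. The expected shift is a 1.2-fold lower number from compound 2 to compound 3 (0.09 log units; within the scatter). For compound 3 the estimated value is 2200 nM, with a range from 900 nM to 5500 nM.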

Compound 3, half-maximal inhibitory concentration: 810 nM
Estimate against measurement, compound 3: 2.7-fold (0.43 log units) above, outside the stated range (below it).
By their numbers in this assay, from the lowest: compounds 3, 1 and 2 (each within the scatter of the next, the first and the last beyond it).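

In this assay, among these compounds, the ring on the carbon with a double bond to nitrogen now shows a clear effect: 2,4-difluorophenyl in place of phenyl gives a 3.4-fold lower number from compound 2 to compound 3 (0.53 log units; beyond the scatter) and is the first step here beyond the scatter. Set against 2,5-dimethoxyphenyl, the same ring gives a 1.9-fold lower number from compound 1 to compound 3 (0.27 log units; within the scatter) so these two substituted rings cannot be told apart. Nothing available explains the difference from phenyl. Still open, going by these compounds, is whether a single fluorine on the phenyl would give the same step, and how a ring carrying chlorine, a nitrile or an amine would read.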